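The source may hold more compounds than are shown below. What is called first, only, known or untested is meant among the compounds shown, and "the series" means these compounds.

Measured compounds in an ADME assay on microsomes from liver (Homo sapiens) for metabolic stability, tested at 2.5 uM; a higher number here means faster removal of the compound, a lower number slower removal:
- compound 1 `O=S(=O)(c1ccc(F)c(Cl)c1)c1cnc2c(F)cccc2c1-c1cccc(Cl)c1` gives 0.18 mL/min
- compound 2 `O=S(=O)(c1cccc(F)c1)c1cnc2c(F)cccc2c1-c1cccc(Cl)c1` gives 0.56 mL/min
- compound 3 `N#Cc1cccc(S(=O)(=O)c2cnc3c(F)cccc3c2-c2cccc(Cl)c2)c1` gives 1.11 mL/min

Compound 3 carries the highest of the three numbers. Its nearest neighbour is compound 2, and the step of a 2.0-fold higher number from compound 2 to compound 3 (0.30 log units; within the scatter) lies within the scatter, so the two are not ordered against each other. Compound 1 sits furthest away; the step of a 6.2-fold higher number from compound 1 to compound 3 (0.79 log units; beyond the scatter) is beyond the scatter, as is a 3.1-fold higher number from compound 1 to compound 2 (0.49 log units; beyond the scatter).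

Compound 4 `O=S(=O)(c1ccc(F)cc1)c1cnc2c(F)cccc2c1-c1cccc(Cl)c1` is the unmeasured member. It differs from compound 3 as follows: 4-fluorophenyl in place of 3-cyanophenyl on a sulfonyl sulfur

Going by the values given here, two measured steps bear on this change. The first, from compound 1 to compound 3, shows that replacing 3-chloro-4-fluorophenyl with 3-cyanophenyl on the sulfonyl sulfur raises the number by a 6.2-fold higher number from compound 1 to compound 3 (0.79 log units; beyond the scatter). The second, from compound 2 to compound 3, shows that cyano in place of fluoro on the aromatic carbon gives only a 2.0-fold higher number from compound 2 to compound 3 (0.30 log units; within the scatter), within the scatter. Compound 4 keeps a single fluorine on the aryl ring, as compound 2 does, but has neither the nitrile of compound 3 nor the chlorine of compound 1. The nearest guide is compound 2 with 0.56 mL/min.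

Compound 4 is therefore expected to sit near compound 2, at about 0.5 mL/min (range 0.25 mL/min to 1 mL/min). The expected step is a 2.2-fold lower number from compound 3 to compound 4 (0.35 log units; beyond the scatter), a modest drop and possibly no more than the scatter.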

Compound 4, intrinsic clearance in a liver preparation (reported as CLH), per the amount of preparation that the assay uses: 1.21 mL/min
Compound 4: middle estimate off by 2.4-fold (0.38 log units), on the low side, outside the stated range (above it).
By their numbers in this assay, from the lowest: compound 1; then compounds 2, 3 and 4 (each within the scatter of the next, the first and the last beyond it).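

In this assay, going by these compounds alone, 4-fluorophenyl in place of 3-fluorophenyl on the sulfonyl sulfur gives a 2.2-fold higher number from compound 2 to compound 4 (0.33 log units; beyond the scatter) and is a modest step, so the place of the single fluorine on this aryl group counts, which the earlier compounds could not show. Hydrogen in place of chloro on an aromatic carbon gives a 6.7-fold higher number from compound 1 to compound 4 (0.83 log units; beyond the scatter) and so, with the fluorine held in place, ties the low number of compound 1 to the chlorine on this aryl group, not to the fluorine alone. The step of a 1.1-fold higher number from compound 3 to compound 4 (0.04 log units; within the scatter) leaves 3-cyanophenyl and 4-fluorophenyl unordered in this assay, so the nitrile is not needed to reach this level in the pair shown.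

No measurement is available that explains why these changes on the aryl group shift the number. Still open, going by these compounds, is whether 3-chlorophenyl without the fluorine, a methoxy or amine group on this ring, or a saturated ring on the sulfonyl sulfur would stay close to compound 1 at 0.18 mL/min or fall in with the other compounds.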